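The source may report more compounds than this note shows. Statements on the series, on what has been measured and on what is new or still open speak of the compounds shown alone.

Compound 1 `CN1CCN(CC(=O)Nc2nc3ccccc3[nH]2)CC1` gives 33.5% in a functional assay, read by spectrophotometry, with a stated time of 30 min, tested at 50 ug/mL; on this read-out lower numbers stand for a weaker effect and higher numbers for a stronger effect at the one concentration tested.
Compound 2 `O=C(CN1CCN(c2ccccc2)CC1)Nc1nc2ccccc2[nH]1` gives 24.1%.
Compound 3 `O=C(CN1CCN(c2ncccn2)CC1)Nc1nc2ccccc2[nH]1` gives 31%.

Compound 3 stands second highest of the three numbers, but its gaps to both neighbours are small: a number 2.5 percentage points lower from compound 1 to compound 3 (within the scatter) and a number 6.9 percentage points higher from compound 2 to compound 3 (within the scatter), so the three compounds cannot be ordered. The untested compound 4 `O=C(CN1CCN(c2ccc([N+](=O)[O-])cc2)CC1)Nc1nc2ccccc2[nH]1` differs from compound 3 in one place: 4-nitrophenyl in place of pyrimidin-2-yl on an amine nitrogen in a ring. Every measured step also changes the group on that same ring nitrogen, and each stayed within the scatter: a number 9.4 percentage points lower from compound 1 to compound 2 (within the scatter), a number 2.5 percentage points lower from compound 1 to compound 3 (within the scatter) and a number 6.9 percentage points higher from compound 2 to compound 3 (within the scatter). Within the data shown here, nothing among the measured compounds tells what 4-nitrophenyl itself does, but none of the three replacements at this position moved the read-out beyond the scatter, so compound 4 is expected to show a step of a number 3 percentage points lower from compound 3 to compound 4 (within the scatter), that is, no change beyond the scatter. Compound 4 is therefore estimated at 28%, with a range from 17% to 38%.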

Compound 4, a percentage reported as activity, at one concentration (the size of the read-out at that concentration, not a potency): 44.8%
Compound 4: the middle estimate sits 16.8 percentage points below what was measured; the measured number lies above the stated range.
By their numbers in this assay, from the lowest: compounds 2, 3 and 1 (each within the scatter of the next); then compound 4.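

Among these compounds, the group on the ring nitrogen is not without effect in this assay: 4-nitrophenyl gives the first steps at this position that lie beyond the scatter, with a number 13.8 percentage points higher from compound 3 to compound 4 (beyond the scatter) and a number 11.3 percentage points higher from compound 1 to compound 4 (beyond the scatter) in the two comparisons with the smaller or nitrogen-containing groups. Phenyl itself could not be separated from methyl, yet nitro in place of hydrogen on an aromatic carbon gives a number 20.7 percentage points higher from compound 2 to compound 4 (beyond the scatter) for the same ring, so the substituent on that aromatic ring matters here. Nothing available explains this rise.

From the compounds shown here alone, it stays open whether the rise is tied to nitro or would also appear with an amine or a nitrile in its place on the phenyl ring. Going by these compounds, whether a carboxylic acid there, or a longer chain between the ring nitrogen and the aromatic ring, would keep the higher read-out also remains open.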